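A carbamate gives way to a cyclic amidine on the piperidine

A few compounds are considered here, and "the series" means these few. Any claim that something is new, unique, unknown or untested is made for them only; others in the source may bear on it.

Of the compounds shown here, three have been tested in a functional assay on CHO-K1 cells for agonist activity at Glucose-dependent insulinotropic receptor (Homo sapiens), read by a luciferase reporter, with a stated time of 5 h; a lower number here means that less compound is needed, a higher number that more compound is needed for the effect. Compound 1 `CC(C)OC(=O)N1CCC(Oc2ncnc3c2CCN3c2ccc(S(C)(=O)=O)cc2)CC1` gives 126 nM, compound 2 `CCCCOC(=O)N1CCC(Oc2ncnc3c2CCN3c2ccc(S(C)(=O)=O)cc2F)CC1` gives 50.1 nM, and the small fragment compound 3 `N#CN1CCC(O)CC1` gives 316 nM. Compound 2 stands lowest of the three; its nearest neighbour is compound 1, whose number is higher by a margin beyond the usual scatter, and compound 3 lies further away still, also beyond the scatter.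

Compound 4 `CS(=O)(=O)c1ccc(N2CCc3c(OC4CCN(C5=NCCCN5)CC4)ncnc32)c(F)c1` has not yet been measured in this assay. It differs from compound 2 in one place: a group of 6 heavy atoms (4 carbon, 2 nitrogen; one six-membered non-aromatic ring with 2 hetero atoms) in place of a group of 7 heavy atoms (5 carbon, 2 oxygen; no ring), on an amine nitrogen in a ring. The butoxycarbonyl that capped the ring amine nitrogen is gone, and in its place sits a six-membered non-aromatic ring with two nitrogen atoms that brings one hydrogen-bond donor.

For the measured compounds named here, no measured pair shows what such a swap does, so the direction of the step must be estimated. Exchanging a carbamate for a ring bearing a donor is a sizeable change, and a moderate rise in the number relative to compound 2 is expected, a 3.0-fold higher number from compound 2 to compound 4 (0.48 log units; beyond the scatter), though a result within the scatter would not surprise. Compound 4 is estimated at 150 nM, with a range from 40 nM to 600 nM.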

Compound 4, half-maximal effective concentration: 2000 nM
Beside the measured number, compound 4's estimate is 13-fold (1.12 log units) below it; measured number above the stated range.
By their numbers in this assay, from the lowest: compound 2; then compound 1; then compound 3; then compound 4.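

In this assay, taking the butoxycarbonyl off the amine nitrogen in the ring and putting the six-membered ring with two nitrogen atoms in its place gives a 40-fold higher number from compound 2 to compound 4 (1.60 log units; beyond the scatter), a large step. For the compounds shown here, this is the first pair that differs only at this position, and it shows that the result is far from indifferent to what sits on that nitrogen, even though the two groups are close in heavy-atom count, 7 leaving and 6 entering, and each has one double bond outside aromatic rings. What the compounds do not explain is why the number climbs so steeply: no measurement here separates the possible reasons for the step.

Going by these compounds, with a single step, it stays open which part of the swap matters: the loss of the two oxygen atoms, the arrival of the ring, or the hydrogen-bond donor that comes with it. A urea, an amide or a pyrimidine ring on the same nitrogen, each set against compound 2, would help to show which features this position can accept.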